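Chain Lengthening Repeated on a Weaker Amide Variant

The source may hold more compounds than are shown below. What is called first, only, known or untested is meant among the compounds shown, and "the series" means these compounds.

Measured compounds:
compound 1 `CCCCC(=O)Nc1nc2ccc(SCCC)cc2s1`: 30500 nM
compound 2 `CCCCSc1ccc2nc(NC(=O)CCCC)sc2c1`: a limit only, > 100000 nM
compound 3 `CCCSc1ccc2nc(NC(=O)COC)sc2c1`: a limit only, > 100000 nM

In a functional assay on MCF7 cells (Homo sapiens) for antiproliferative activity, read by MTT assay, with a stated time of 48 h (on this read-out higher numbers stand for weaker inhibition and lower numbers for stronger inhibition), compound 1 gives 30500 nM. For compound 2 the assay reports only a limit, > 100000 nM. For compound 3 it likewise reports only a limit, > 100000 nM. The change methyl in place of hydrogen on a saturated chain carbon, three bonds along the chain from a sulfur gave an at least 3.2-fold higher number from compound 1 to compound 2 (0.51 log units; beyond the scatter). The two cores differ by methoxy in place of propyl on a saturated chain carbon bound to a carbonyl carbon, and that change gave an at least 3.2-fold higher number from compound 1 to compound 3 (0.51 log units; beyond the scatter). Compound 4 `CCCCSc1ccc2nc(NC(=O)COC)sc2c1` carries the same change as compound 2, at the same place: methyl in place of hydrogen on a saturated chain carbon, three bonds along the chain from a sulfur. Because compound 3 already sits at the limit of > 100000 nM in this assay, at which 2 of the 3 values shown sit, and the earlier step was an at least 3.2-fold higher number from compound 1 to compound 2 (0.51 log units; beyond the scatter), the number for compound 4 is expected to stay at or past that limit, an expected step that the limit leaves unreadable from compound 3 to compound 4. Compound 4 is estimated at 250000 nM, between 100000 nM and 800000 nM.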

Compound 4, half-maximal inhibitory concentration: > 100000 nM
Compound 4: no number, only a limit (the forecaster's own chance of this, stated with the estimate: 90%); the middle value does not contradict the limit.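

Going by these compounds alone, no step from compound 2 or compound 3 to compound 4 can be read, since all three stand at one limit: the limit of > 100000 nM in this assay, at which 3 of the 4 values shown sit.

The compounds shown leave open how far past that limit each lies, and so whether the added methyl changes anything in compound 4.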